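The compounds below may be only part of what the source reports. "The series", "measured", "known", "first", "only" and "open" are said of these compounds alone.

Measured compounds in an assay for inhibition of liver carboxylesterase 1 (Homo sapiens), read by spectrophotometry; on this read-out higher numbers stand for weaker inhibition and lower numbers for stronger inhibition:

Compound 1, `CCOc1ccc(NS(=O)(=O)c2ccc(Cl)cc2)cc1`, gives in this assay > 100000 nM, which is a limit of the assay and not a number.
Compound 2, `O=C(O)c1ccc(S(=O)(=O)Nc2ccc(NS(=O)(=O)c3ccc(F)cc3)cc2)cc1`, gives in this assay > 100000 nM, again a limit of the assay and not a number.

Where compound 2 stands: both values shown sit at the same limit, as noted in the limit of > 100000 nM in this assay, at which 2 of the 2 values shown sit, so nothing can be said about any order between compound 1 and compound 2, and no measured step exists in the series.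

Compound 3, `O=S(=O)(Nc1ccc(NS(=O)(=O)c2ccc(Cl)cc2)cc1)c1ccc(F)cc1`, remains to be measured in this assay. It differs from compound 2 by chloro in place of carboxy on an aromatic carbon. Among the compounds with values here, no step between measured compounds carries this change. Compound 1 also bears a chloro and sits at the limit, but it is not a single-change neighbour of compound 2 or of compound 3, so it gives only a loose hint.

With both measured values at the limit, the step from compound 2 to compound 3 is expected to show no change beyond the scatter, a number no higher from compound 2 to compound 3 (the limit leaves the size open). Compound 3 is therefore estimated at 100000 nM, with a range from 20000 nM to 400000 nM, and most likely reported only as a limit.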

Compound 3, inhibition constant: > 100000 nM
Compound 3: only a limit was reported; the forecaster's own chance of this, stated with the estimate: 70%; the middle value sits exactly at the limit.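

In this assay compound 3 gives > 100000 nM, a limit of the assay and not a number, so no step can be read from compound 2 to compound 3: the limit of > 100000 nM in this assay, at which 3 of the 3 values shown sit.

The compounds shown leave open what chloro in place of carboxy does in this assay, and whether any compound in this series reaches a readable number.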